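This account rests on a few compounds, and the source may have more. Where it says the series, first, only, none or still open, it means among the compounds named here.

In a functional assay on PC-3 cells (Homo sapiens) for inhibition, read by MTT assay, with stated times of 18 h and 4 h (a higher number here means a weaker inhibitor, a lower number a stronger inhibitor), compound 1 `CCCCCCCCCCCCCCCCOP(=O)(O)OCCSC(=S)N1CCCCCC1` gives 32100 nM, the only exact figure available so far. Compound 2 `CCCCCCCCOP(=O)(O)OCCSC(=S)N1CCCC1` gives > 100000 nM, which is a limit and not a number. Compound 3 `CCCCCCCCCCOP(=O)(O)OCCSC(=S)N1CCCCCC1` keeps the core of compound 1 but carries a shorter chain, with hydrogen in place of hexyl on a saturated chain carbon, ten or more bonds along the chain from an oxygen on an unsaturated carbon. Among the measured compounds shown here, no two measured compounds differ in one place only, so this change has no direct precedent. In this assay, for the measured compounds named here, a move toward weaker inhibition is expected, modest in size and probably just beyond the scatter, given that the only other reading is the limit of > 100000 nM in this assay, at which 1 of the 2 values shown sits. The expected change is a 2.0-fold higher number from compound 1 to compound 3 (0.31 log units; beyond the scatter). For compound 3, the estimate is 65000 nM, with an expected range of 30000 nM to 140000 nM.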

Compound 3, half-maximal inhibitory concentration: 32900 nM
The estimate for compound 3 lay 2.0-fold (0.30 log units) above the measured number; measured number inside the range.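

Among the compounds shown here, the step of a 1.0-fold higher number from compound 1 to compound 3 (0.01 log units; within the scatter) in this assay is the first direct reading at this position, on a saturated chain carbon. With the core of compound 1 held fixed, hexyl and hydrogen at this place read alike, so this part of the chain can be cut back with no difference beyond the scatter. Nothing shown gives a reason for this result.

Going by these compounds, whether a longer chain, or an amine or a carboxylic acid at this place, would also read alike stays open. Compound 2 gives > 100000 nM, which is a limit and not a number, and it differs from the other two compounds in more than one place, so its chain length cannot be judged on its own.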